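Compound 1 to compound 4: a phenyl swap

The compounds below may be only part of what the source reports. "The series", "measured", "known", "first", "only" and "open" are said of these compounds alone.

In an ADME assay on microsomes from liver (Homo sapiens) for metabolic stability (on this read-out higher numbers stand for fast clearance and lower numbers for slow clearance), compound 1 `Cn1ncc(-c2nn(C)c3ncnc(N4CCC4)c23)c1-c1ccc(C(F)(F)F)cn1` gives 33 mL/min/kg. Compound 2 `Cc1ccc(-c2c(-c3nn(C)c4ncnc(N5CCC5)c34)cnn2C)cc1` gives 47 mL/min/kg, and compound 3 `Cn1ncc(-c2nn(C)c3ncnc(N4CCC4)c23)c1-c1ccc(C2CC2)cc1` gives 90 mL/min/kg. Compound 1 therefore has no clear gap to compound 2 but a clear one to compound 3.

The next structure is compound 4 `Cn1ncc(-c2nn(C)c3ncnc(N4CCC4)c23)c1-c1ccccc1`, which carries phenyl in place of 5-(trifluoromethyl)pyridin-2-yl on an aromatic carbon.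

Two measured steps replace the same group at the same place, each with a substituted phenyl. The first is a 1.4-fold higher number from compound 1 to compound 2 (0.15 log units; within the scatter). The second is a 2.7-fold higher number from compound 1 to compound 3 (0.44 log units; beyond the scatter). The swap of methyl for cyclopropyl that links them gives a 1.9-fold higher number from compound 2 to compound 3 (0.28 log units; within the scatter). Within the data shown here, no measured compound carries phenyl itself, so the guidance is indirect and rests on only these three compounds. The smaller step, a 1.4-fold higher number from compound 1 to compound 2 (0.15 log units; within the scatter), is taken as the main guide, while the larger one, a 2.7-fold higher number from compound 1 to compound 3 (0.44 log units; beyond the scatter), sets the upper side of the range. The expected change is a small upward one that stays within the scatter, a 1.3-fold higher number from compound 1 to compound 4 (0.10 log units; within the scatter). For compound 4 the estimated clearance is 42 mL/min/kg, with an expected range of 22 mL/min/kg to 75 mL/min/kg.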

Compound 4, clearance: 34 mL/min/kg
Compound 4: middle estimate off by 1.2-fold (0.09 log units), on the high side; measured number inside the range.
By their numbers in this assay, from the lowest: compounds 1, 4, 2 and 3 (each within the scatter of the next, the first and the last beyond it).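

In this assay, phenyl and 5-(trifluoromethyl)pyridin-2-yl cannot be told apart on this aromatic carbon: a 1.0-fold higher number from compound 1 to compound 4 (0.01 log units; within the scatter) is the whole effect of removing the ring nitrogen and the trifluoromethyl group together. Among the phenyl compounds, the substituent decides whether a gap can be read, since a 2.6-fold lower number from compound 3 to compound 4 (0.42 log units; beyond the scatter) marks cyclopropyl as standing apart from hydrogen, while a 1.4-fold lower number from compound 2 to compound 4 (0.14 log units; within the scatter) gives no such separation for methyl. The high number of compound 3 therefore goes with the cyclopropyl substituent rather than with the change of ring, but no supporting measurement explains any of these steps.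

Still open, going by these compounds, is how a pyridin-2-yl without trifluoromethyl, or a phenyl bearing trifluoromethyl, would behave in this assay, as either compound would separate the two parts of the change from compound 1 to compound 4. Also open, on these data alone, is how far this aromatic carbon tolerates other phenyl substituents, such as a methoxy group, an amine or a carboxylic acid.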